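This account rests on a few compounds, and the source may have more. Where it says the series, first, only, none or still open, it means among the compounds named here.

The shared core carries compound 1 `C#Cc1cn([C@@H]2O[C@H](CO)[C@@H](O)[C@H]2O)c2ncnc(OC)c12`, compound 2 `COc1ncnc2c1c(-c1cccs1)cn2[C@@H]1O[C@H](CO)[C@@H](O)[C@H]1O` and compound 3 `COc1ncnc2c1c(-c1ccccc1)cn2[C@@H]1O[C@H](CO)[C@@H](O)[C@H]1O`. In a functional assay on HCT-116 cells (Homo sapiens), read by MTT assay, with a stated time of 72 h (a lower number here means a stronger inhibitor, a higher number a weaker inhibitor), compound 1 gives 4060 nM, and compound 2 gives 80 nM. Compound 3 reaches only the limit > 20000 nM, so it stands beyond every number shown, at the limit of > 20000 nM in this assay, at which 1 of the 3 values shown sits. The step of an at least 250-fold higher number from compound 2 to compound 3 (2.39 log units; beyond the scatter) and the step of an at least 4.9-fold higher number from compound 1 to compound 3 (0.69 log units; beyond the scatter) both lead down into that limit. Compound 4 `COc1ncnc2c1c(-c1ccco1)cn2[C@@H]1O[C@H](CO)[C@@H](O)[C@H]1O` has not yet been measured. furan-2-yl in place of phenyl on an aromatic carbon Since this change reverses the kind of step seen in an at least 250-fold higher number from compound 2 to compound 3 (2.39 log units; beyond the scatter), bringing back a five-membered aromatic ring with 1 hetero atom, a large fall in this assay is expected for compound 4, by about an at least 66-fold lower number from compound 3 to compound 4 (1.82 log units; beyond the scatter). Compound 4 is therefore estimated at 300 nM, between 60 nM and 3000 nM.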

Compound 4, half-maximal inhibitory concentration: 40 nM
Compound 4: the middle estimate sits 7.5-fold (0.88 log units) above what was measured; measured number below the stated range.
By their numbers in this assay, from the lowest: compounds 4 and 2 (each within the scatter of the next); then compound 1. At a limit, above all of these: compound 3.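

The hetero atom of the five-membered ring can be oxygen as well as sulfur at this position: furan-2-yl in place of thiophen-2-yl gives a 2.0-fold lower number from compound 2 to compound 4 (0.30 log units; within the scatter), which lies within the scatter. Furan-2-yl in place of ethynyl gives a 100-fold lower number from compound 1 to compound 4 (2.01 log units; beyond the scatter), so a second five-membered ring also stands well clear of the ethynyl group. Furan-2-yl in place of phenyl gives an at least 500-fold lower number from compound 3 to compound 4 (2.69 log units; beyond the scatter), a step that rests on a limit for compound 3: the limit of > 20000 nM in this assay, at which 1 of the 4 values shown sits.

The compounds shown leave open whether a nitrogen-containing ring, such as pyrrol-2-yl or pyridin-2-yl, would behave like furan-2-yl. They also leave open whether attachment through another ring carbon, as in furan-3-yl, would matter.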